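The source may report more compounds than this note shows. Statements on the series, on what has been measured and on what is new or still open speak of the compounds shown alone.

Measured in a functional assay on SW620/5-FU cells (Homo sapiens) for cytotoxicity, read by MTT assay, with a stated time of 48 h, in the presence of a further agent that is not named here; a lower number here means that less compound is needed, a higher number that more compound is needed for the effect:
- compound 1 `Cc1nn(C)c2nc(NNC(=O)Nc3cc(Cl)nc(Cl)c3)cc(C3CC3)c12`: 80800 nM
- compound 2 `COc1cc(NC(=O)NNc2cc(-c3ccc(F)cc3)c3cnn(C)c3n2)cc(OC)c1OC`: 39200 nM
- compound 3 `CC(C)c1cc(NNC(=O)Nc2cc(Cl)nc(Cl)c2)nc2c1cnn2C`: 50100 nM

Compound 1 stands at the high end of these numbers. It lies within the scatter of compound 3, while compound 2 lies beyond the scatter on the lower side. Compound 4 `Cc1nn(C)c2nc(NNC(=O)Nc3cc(Cl)nc(Cl)c3)cc(-c3ccccc3)c12` keeps the core of compound 1 but has phenyl in place of cyclopropyl on an aromatic carbon. Among the compounds with values here, no measured pair isolates this change. Compound 2, which also carries a six-membered aromatic ring of carbon only, gives 39200 nM, so a small downward step or none beyond the scatter is expected. The estimated step of a 1.5-fold lower number from compound 1 to compound 4 (0.17 log units; within the scatter) stays within the scatter. In this assay the estimate for compound 4 is 55000 nM, with an expected range of 22000 nM to 110000 nM.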

Compound 4, half-maximal effective concentration: 22900 nM
The estimate for compound 4 lay 2.4-fold (0.38 log units) above the measured number; the range from low to high includes it.
By their numbers in this assay, from the lowest: compounds 4, 2, 3 and 1 (each within the scatter of the next, the first and the last beyond it).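

In this assay, within the data shown here, phenyl in place of cyclopropyl on an aromatic carbon gives a 3.5-fold lower number from compound 1 to compound 4 (0.55 log units; beyond the scatter) and provides the first single-place comparison at this position. The group on this carbon therefore changes the number beyond the scatter, with the six-membered aromatic ring needing less compound than the three-membered non-aromatic ring. Nothing available explains this step.

The compounds shown leave open whether an amine or a carboxylic acid on this carbon would give a number as low as phenyl does. They also leave open whether the same step would hold on another core.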